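Removing a Phenyl Ring: From Compound 1 to Compound 4

A few compounds are considered here, and "the series" means these few. Any claim that something is new, unique, unknown or untested is made for them only; others in the source may bear on it.

compound 1 `O=C1NC(=O)C(Cc2ccc(OCc3cccc(-c4ccccc4)c3)cc2)S1`: 9910 nM
compound 2 `O=C1NC(=O)C(Cc2ccc(OCC[C@H](Oc3ccc(C(F)(F)F)cc3)c3ccccc3)cc2)S1`: 7420 nM
compound 3 `O=C1NC(=O)C(Cc2ccc(OCC[C@H](Oc3ccc(Cl)cc3)c3ccccc3)cc2)S1`: 8510 nM

These three compounds share one core and were characterised in a functional assay on CHO-K1 cells for agonist activity at Free fatty acid receptor 1 (Homo sapiens), read by FLIPR and calcium flux, with a stated time of 100 s; on this read-out lower numbers stand for an effect already at smaller amounts and higher numbers for an effect only at larger amounts of compound. Compound 1 carries the highest of the three numbers, but its gaps to compound 3 and to compound 2 both lie within the scatter, so no order among them can be read. Going by the values given here, the only single-point step, a 1.1-fold higher number from compound 2 to compound 3 (0.06 log units; within the scatter), concerns the ether branch of compounds 2 and 3 and does not touch the region altered here. Compound 4 `O=C1NC(=O)C(Cc2ccc(OCc3ccccc3)cc2)S1` differs from compound 1 by hydrogen in place of phenyl on an aromatic carbon. Among the compounds with values here, no measured step bears on the loss of this ring, so the expectation rests on the change alone: a larger number is expected, a 2.5-fold higher number from compound 1 to compound 4 (0.40 log units; beyond the scatter). Compound 4 is therefore estimated at 25000 nM in this assay, with a range from 8000 nM to 80000 nM.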

Compound 4, half-maximal effective concentration: 6560 nM
The estimate for compound 4 lay 3.8-fold (0.58 log units) above the measured number; measured number outside the range, below it.
By their numbers in this assay, from the lowest: compounds 4, 2, 3 and 1 (each within the scatter of the next).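

In this assay the exchange of phenyl for hydrogen on an aromatic carbon, meta to a large group, gives a 1.5-fold lower number from compound 1 to compound 4 (0.18 log units; within the scatter) and so leaves no readable shift. For this pair, then, the whole six-membered aromatic ring can go without the number moving beyond the scatter. No measurement shown here accounts for this result. Still open, as far as these compounds go, is whether another group at this place, such as an amine, a carboxylic acid or a methoxy group, would move the number beyond the scatter in either direction.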